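Caspase-8 series: hydroxymethyl variant of the dihydroazepinone lactam core

The compounds below may be only part of what the source reports. "The series", "measured", "known", "first", "only" and "open" are said of these compounds alone.

Measured compounds and their numbers in an assay on isolated protein for inhibition of Caspase-8 (Homo sapiens); on this read-out higher numbers stand for weaker inhibition and lower numbers for stronger inhibition:
compound 1 `O=C(CN1CC=CC[C@H](NC(=O)c2cccc(Cl)c2)C1=O)N[C@H]1CC(=O)OC1O`: 1180 nM
compound 2 `O=C(CN1CC=CC[C@H](NC(=O)c2nccc3ccccc23)C1=O)N[C@H]1CC(=O)OC1O`: 2940 nM
compound 3 `CC1=CC[C@H](NC(=O)c2ccc3ccccc3c2)C(=O)N(CC(=O)N[C@H]2CC(=O)OC2O)C1`: 2690 nM

Compound 3 stands second highest of the three numbers. Compound 2 lies nearest to it and the two are within the scatter of each other, so no order between them is claimed. Compound 1 lies furthest, beyond the scatter, with the lower number.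

Among the measured compounds shown here, the one measured step, a 2.5-fold higher number from compound 1 to compound 2 (0.40 log units; beyond the scatter), concerns an exchange of the aryl group on the carbonyl carbon and leaves the ring substituent untouched. It therefore does not bear on the change now considered.

Compound 4 `O=C(CN1CC(CO)=CC[C@H](NC(=O)c2ccc3ccccc3c2)C1=O)N[C@H]1CC(=O)OC1O` differs from compound 3 in one place: hydroxy in place of hydrogen on a saturated chain carbon bound to a double-bonded ring carbon. The shared core, the naphthoyl amide and the lactone portion are unchanged. For the measured compounds named here, no measured pair in this set varies that ring substituent, so nothing here speaks for a shift in either direction.

For compound 4 the step of a 1.0-fold lower number from compound 3 to compound 4 (0.01 log units; within the scatter) is expected to stay within the scatter. Compound 4 is estimated at 2600 nM in this assay, with a range of 1200 nM to 5600 nM.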

Compound 4, half-maximal inhibitory concentration: 2110 nM
Estimate against measurement, compound 4: 1.2-fold (0.09 log units) above; measured number inside the range.
By their numbers in this assay, from the lowest: compounds 1, 4, 3 and 2 (each within the scatter of the next, the first and the last beyond it).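

In this assay, hydroxy in place of hydrogen on a saturated chain carbon bound to a double-bonded ring carbon, the same difference as methyl to hydroxymethyl, gives a 1.3-fold lower number from compound 3 to compound 4 (0.11 log units; within the scatter) and so stays within the scatter. This is the only pair shown that varies this ring substituent, and it shows that adding the hydroxy here, with the naphthoyl amide held constant, produces no shift that can be claimed in either direction. No supporting data bear on this result.

As far as these compounds go, the change is read on the naphthoyl amide alone, so its effect alongside other aryl groups on the carbonyl carbon remains open. Also open, from the compounds shown here alone, is how an amine, a carboxylic acid or a longer chain ending in hydroxy would read in place of the hydroxymethyl.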